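From pyridin-3-yl to 2-methylphenyl: an expected loss of potency

The compounds below may be only part of what the source reports. "The series", "measured", "known", "first", "only" and "open" are said of these compounds alone.

Three compounds have been measured in a functional assay on CHO cells for agonist activity at Alpha-2C adrenergic receptor (Homo sapiens); on this read-out higher numbers stand for an effect only at larger amounts of compound and lower numbers for an effect already at smaller amounts:

compound 1 `Cc1ccc(-c2ccccc2OC(C)C2=NCCN2)cc1` — 832 nM
compound 2 `CC(Oc1ccccc1-c1cccnc1)C1=NCCN1` — 50.1 nM
compound 3 `CC(Nc1ccccc1-c1ccccc1)C1=NCCN1` — 93.3 nM

Compound 2 gives the lowest of the three numbers. Compound 3 lies close to it, within the scatter of the method, so the two cannot be ranked against each other. Compound 1 sits far above both, as the step of a 17-fold lower number from compound 1 to compound 2 (1.22 log units; beyond the scatter) shows.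

Compound 4 `Cc1ccccc1-c1ccccc1OC(C)C1=NCCN1` has not yet been measured in this assay. It differs from compound 2 in a single place: 2-methylphenyl in place of pyridin-3-yl on an aromatic carbon. Among the measured compounds shown here, only one measured step bears on this change, namely a 17-fold lower number from compound 1 to compound 2 (1.22 log units; beyond the scatter), in which 4-methylphenyl gave way to pyridin-3-yl. The present change runs in the opposite sense, restoring a carbon-only ring in place of the ring with one nitrogen, although the entering group is 2-methylphenyl rather than the 4-methylphenyl of compound 1, so the earlier step is a guide but not an exact mirror.

On that basis the step of an 8.0-fold higher number from compound 2 to compound 4 (0.90 log units; beyond the scatter) is expected: an upward move, probably smaller than the earlier one because the step of a 17-fold lower number from compound 1 to compound 2 (1.22 log units; beyond the scatter) was measured with 4-methylphenyl and not with the 2-methylphenyl that enters here. The estimate for compound 4 is 400 nM, expected to fall between 120 nM and 1300 nM.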

Compound 4, half-maximal effective concentration: 363 nM
Beside the measured number, compound 4's estimate is 1.1-fold (0.04 log units) above it; measured number inside the range.
By their numbers in this assay, from the lowest: compounds 2 and 3 (each within the scatter of the next); then compound 4; then compound 1.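

With 2-methylphenyl on the same aromatic carbon, ortho to a group of 8 heavy atoms, this assay shows a 7.2-fold higher number from compound 2 to compound 4 (0.86 log units; beyond the scatter) and so extends the earlier finding: the rise in the number on leaving pyridin-3-yl is not confined to 4-methylphenyl, and both carbon-only rings now give higher numbers than the ring with one nitrogen. The two methylphenyl groups are also not interchangeable, as a 2.3-fold lower number from compound 1 to compound 4 (0.36 log units; beyond the scatter) is a modest step but lies beyond the scatter, which shows that where the methyl stands on the entering ring has a measurable bearing on the result. Nothing available explains either step or ties it to a property of these groups.

Still open, from the compounds shown here alone, is how much of the step from pyridin-3-yl belongs to losing the ring nitrogen and how much to gaining the methyl, since the two changes occur together here and a plain phenyl on this carbon of the core of compound 2 would separate them. Also open, going by these compounds, is how pyridin-4-yl, or a methoxy or trifluoromethyl group on the carbon-only ring in place of the methyl, would fit into this order.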